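The compounds below may be only part of what the source reports. "The series", "measured", "known", "first", "only" and "open" are said of these compounds alone.

Measured in a functional assay on HepG2 cells (Homo sapiens) for inhibition, read by MTT assay, with a stated time of 72 h; on this read-out lower numbers stand for stronger inhibition and higher numbers for weaker inhibition:
compound 1 `Cn1ccc2c(Oc3ccc(NC(=O)c4cn(-c5ccc(F)cc5)c5ccccc5c4=O)cc3F)ccnc21`: 2010 nM
compound 3 `COc1ccc(-n2cc(C(=O)Nc3ccc(Oc4ccnc5c4ccn5C)c(F)c3)c(=O)c3ccccc32)cc1`: 3750 nM
compound 2 `Cn1ccc2c(Oc3ccc(NC(=O)c4cn(-c5ccc(C(F)(F)F)cc5Cl)c5ccccc5c4=O)cc3F)ccnc21`: "not determined" (no result reported)

Among the compounds with values here, compound 1 and compound 3 lie within the scatter of each other; the only single-point step in this set, a 1.9-fold higher number from compound 1 to compound 3 (0.27 log units; within the scatter), is a change on the aromatic carbon of the pendant ring and does not reach beyond the scatter. Compound 4 `O=C(Nc1ccc(Oc2ccnc3[nH]ccc23)c(F)c1)c1cn(-c2ccc(F)cc2)c2ccccc2c1=O` differs from compound 1 by hydrogen in place of methyl on an aromatic nitrogen. Within the data shown here, no measured step touches this aromatic nitrogen, so nothing in the set bears directly on the change; the one known step suggests that small peripheral changes leave the read-out within the scatter. For compound 4 the expected step is therefore a 1.2-fold higher number from compound 1 to compound 4 (0.09 log units; within the scatter), none beyond the scatter. The estimate for compound 4 in this assay is 2500 nM, with a range of 900 nM to 7000 nM.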

Compound 4, half-maximal inhibitory concentration: 270 nM
For compound 4 the middle estimate is 9.3-fold (0.97 log units) above the measured one, and the stated range ends above it.
By their numbers in this assay, from the lowest: compound 4; then compounds 1 and 3 (each within the scatter of the next).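

In this assay, within the data shown here, the aromatic nitrogen of the five-membered ring is a position where a single small change moves the read-out: hydrogen in place of methyl gives a 7.4-fold lower number from compound 1 to compound 4 (0.87 log units; beyond the scatter), the only step in this set beyond the scatter. The earlier step on the pendant ring, a 1.9-fold higher number from compound 1 to compound 3 (0.27 log units; within the scatter), gave no such sign. No available evidence accounts for the size of this step.

As far as these compounds go, it remains open whether an ethyl group or a longer chain on this nitrogen would track with methyl or hydrogen. Also open, from the compounds shown here alone, is whether the lower number carries over to the methoxy compound 3.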